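Methyl at the core of a pyrrolopyrimidinone sulfonamide series

A few compounds are considered here, and "the series" means these few. Any claim that something is new, unique, unknown or untested is made for them only; others in the source may bear on it.

Two compounds of the series have numbers in a functional assay on HepG2 cells (Homo sapiens) for inhibition, read by sulforhodamine B assay, with a stated time of 24 h; on this read-out lower numbers stand for stronger inhibition and higher numbers for weaker inhibition. Compound 1 `O=c1[nH]cnc2c1c(-c1ccccc1)cn2-c1ccc(S(=O)(=O)Nc2nccs2)cc1` gives 5300 nM and compound 2 `O=c1[nH]cnc2c1c(-c1ccccc1)cn2-c1ccc(S(=O)(=O)Nc2ccccn2)cc1` gives 4670 nM. Among the measured compounds shown here, compound 1 stands with the highest of the two numbers; the nearest is compound 2, and the only measured step, a 1.1-fold lower number from compound 1 to compound 2 (0.05 log units; within the scatter), lies within the scatter. Compound 3 `Cc1nc2c(c(-c3ccccc3)cn2-c2ccc(S(=O)(=O)Nc3nccs3)cc2)c(=O)[nH]1` is not yet measured. It differs from compound 1 by methyl in place of hydrogen on an aromatic carbon. For the measured compounds named here, no measured step touches this part of the shared core: the single step measured concerns the group on the sulfonamide nitrogen, not the fused ring system. For compound 3 the expected step is therefore none beyond the scatter, a 1.1-fold lower number from compound 1 to compound 3 (0.03 log units; within the scatter), in this assay. Compound 3 is thus estimated at 5000 nM in this assay, with a range from 2000 nM to 12500 nM.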

Compound 3, half-maximal inhibitory concentration: 3390 nM
Compound 3: the middle estimate sits 1.5-fold (0.17 log units) above what was measured, within the range that was stated.
By their numbers in this assay, from the lowest: compounds 3, 2 and 1 (each within the scatter of the next).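

In this assay, methyl in place of hydrogen on an aromatic carbon, between two ring nitrogen atoms, gives a 1.6-fold lower number from compound 1 to compound 3 (0.19 log units; within the scatter). Among the compounds shown here, this is the first reading from the shared core itself, since the earlier pair varied only the group on the sulfonamide nitrogen, and it shows that this position carries a methyl without a step beyond the scatter. No supporting measurement bears on this result.

On these data alone, whether a longer chain or an amine at the same position would stay within the scatter remains open, as a single methyl sets no limit on what the position carries. Also open, as far as these compounds go, is whether the same methyl gives a similar step when the group on the sulfonamide nitrogen is pyridin-2-yl, as in compound 2.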